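Swapping a lactam for diisopropylamino on a nucleoside

A few compounds are considered here, and "the series" means these few. Any claim that something is new, unique, unknown or untested is made for them only; others in the source may bear on it.

Compound 1 `CN(Cc1ncnc2c1ncn2[C@@H]1O[C@H](CO)[C@@H](O)[C@H]1O)c1ccccc1`: 21000 nM
Compound 2 `O=c1ccn(Cc2ncnc3c2ncn3[C@@H]2O[C@H](CO)[C@@H](O)[C@H]2O)cc1`: > 100000 nM (a limit)
Compound 3 `O=C1CCCN1Cc1ncnc2c1ncn2[C@@H]1O[C@H](CO)[C@@H](O)[C@H]1O`: 45000 nM

In a functional assay on Huh-7 cells (Homo sapiens) for cytotoxicity, read by MTT assay, with a stated time of 3 days (a higher number here means that more compound is tolerated, a lower number that less compound is tolerated), compound 3 gives 45000 nM, the higher of the two true numbers. Among the compounds with values here, the only other number belongs to compound 1, and the gap is a 2.1-fold higher number from compound 1 to compound 3 (0.33 log units; beyond the scatter). Compound 2 gives > 100000 nM, which is a limit of the assay and not a number.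

The next compound is compound 4 `CC(C)N(Cc1ncnc2c1ncn2[C@@H]1O[C@H](CO)[C@@H](O)[C@H]1O)C(C)C`, which carries diisopropylamino in place of 2-oxopyrrolidin-1-yl on a saturated chain carbon bound to an aromatic carbon. The group that enters has no ring and no double bond outside aromatic rings. Within the data shown here, no measured step makes this exact change. The nearest guide is compound 1, whose methyl(phenyl)amino group is also an amino group without a carbonyl, and the step there was a 2.1-fold higher number from compound 1 to compound 3 (0.33 log units; beyond the scatter). The two carbonyl-bearing groups both sit higher than compound 1, with an at least 4.7-fold higher number from compound 1 to compound 2 (0.67 log units; beyond the scatter) as the larger gap, and an at least 2.2-fold lower number from compound 2 to compound 3 (0.34 log units; beyond the scatter) separates them. A small move to a lower number is therefore expected, close to the edge of the scatter. The estimated step is a 1.8-fold lower number from compound 3 to compound 4 (0.26 log units; within the scatter). For compound 4 the expected value is 25000 nM, with an estimated range of 9000 nM to 70000 nM.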

Compound 4, half-maximal cytotoxic concentration: 18000 nM
Compound 4: middle estimate off by 1.4-fold (0.14 log units), on the high side; the measured number falls inside the stated range.
By their numbers in this assay, from the lowest: compounds 4 and 1 (each within the scatter of the next); then compound 3. At a limit, above all of these: compound 2.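

In this assay, within the data shown here, diisopropylamino in place of 2-oxopyrrolidin-1-yl on a saturated chain carbon bound to an aromatic carbon gives a 2.5-fold lower number from compound 3 to compound 4 (0.40 log units; beyond the scatter), the first direct reading of a lactam giving way to an open dialkylamino group at this place. The two amino groups without a carbonyl cannot be told apart, with a 1.2-fold lower number from compound 1 to compound 4 (0.07 log units; within the scatter), so the aromatic ring of methyl(phenyl)amino is not required for a number at this level, and compounds 1 and 4 both sit lower than the two carbonyl-bearing compounds, with no compound shown going against this. The remaining step reads an at least 5.5-fold lower number from compound 2 to compound 4 (0.74 log units; beyond the scatter), and it is only a bound, since compound 2 stands at a limit of the assay and not at a number: the limit of > 100000 nM in this assay, at which 1 of the 4 values shown sits.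

The compounds shown leave open whether the higher numbers go with the carbonyl or with the ring that holds it. A piperidin-1-yl group, which has the ring without the carbonyl, and an acetamido group, which has the carbonyl without the ring, would separate the two on the same saturated chain carbon.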